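From a Large Side Group to a Small One

The source may report more compounds than this note shows. Statements on the series, on what has been measured and on what is new or still open speak of the compounds shown alone.

In a functional assay on MCF7 cells (Homo sapiens) for antiproliferative activity, read by MTT assay, with a stated time of 72 h (a higher number here means a weaker inhibitor, a lower number a stronger inhibitor), compound 1 (`CCCCc1cn(C[C@H](O)[C@H]2OC(=O)C(OCc3ccccc3)=C2OCc2ccccc2)nn1`) gives 7910 nM as its value, compound 2 (`CCCCCCCCCCc1cn(C[C@H](O)[C@H]2OC(=O)C(OCc3ccccc3)=C2OCc2ccccc2)nn1`) gives 80 nM as its value, and compound 3 (`O=C1O[C@H]([C@@H](O)Cn2cc(CNS(=O)(=O)c3ccc(Cl)cc3)nn2)C(OCc2ccccc2)=C1OCc1ccccc1`) gives 4170 nM on the same read-out. Two steps fix the standing of compound 3. The first is a 1.9-fold lower number from compound 1 to compound 3 (0.28 log units; within the scatter) and so leaves it level with the short-chain compound. The second is a 52-fold higher number from compound 2 to compound 3 (1.72 log units; beyond the scatter) and so sets it far above the long-chain compound.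

Compound 4 (`C[Si](C)(C)c1cn(C[C@H](O)[C@H]2OC(=O)C(OCc3ccccc3)=C2OCc2ccccc2)nn1`) keeps the shared core and differs from compound 3 as follows: a group of 4 heavy atoms (3 carbon, 1 silicon; no ring) in place of a group of 12 heavy atoms (7 carbon, 1 nitrogen, 2 oxygen, 1 sulfur, 1 chlorine; one six-membered aromatic ring of carbon only), on an aromatic carbon and the entering group has no ring and no hydrogen-bond donors. Going by the values given here, no measured step makes this exact exchange. The closest guide is a 99-fold lower number from compound 1 to compound 2 (2.00 log units; beyond the scatter) and it shows how far a long chain moved the number in this series. The entering group carries no such long chain, so compound 4 is expected to resemble compound 1 at 7910 nM rather than compound 2 at 80 nM in its value. In this assay no step beyond the scatter is therefore expected, though any drift should be towards a higher number. The estimate amounts to a 1.7-fold higher number from compound 3 to compound 4 (0.22 log units; within the scatter) as the expected step. For compound 4 the estimated value is 7000 nM with an expected range from 2500 nM to 20000 nM as the likely span.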

Compound 4, half-maximal inhibitory concentration: 12100 nM
For compound 4 the middle estimate is 1.7-fold (0.24 log units) below the measured one; the measured number falls inside the stated range.
By their numbers in this assay, from the lowest: compound 2; then compounds 3, 1 and 4 (each within the scatter of the next, the first and the last beyond it).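

Exchanging the short chain in compound 1 for the group of 3 carbon atoms and 1 silicon atom on the same aromatic carbon gives a 1.5-fold higher number from compound 1 to compound 4 (0.18 log units; within the scatter) in this assay, so placing silicon in a group of this size leaves the number within the scatter of the all-carbon group. Set against the group of 10 carbon atoms in compound 2, the same silicon group gives a 150-fold higher number from compound 2 to compound 4 (2.18 log units; beyond the scatter), which shows that silicon at this place does not bring the number near that of the long chain. The exchange for (((4-chlorophenyl)sulfonyl)amino)methyl gives a 2.9-fold higher number from compound 3 to compound 4 (0.46 log units; beyond the scatter), a modest separation that compound 3 does not show from compound 1, whose step to compound 3 lies within the scatter.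

Nothing available bears on why the numbers fall as they do.

The compounds shown leave open how the number changes along the way from the short chain to the long one, as with an octyl chain, and whether a dodecyl chain would go lower still. They also leave open whether a long chain containing silicon, or one ending in an amine or a carboxylic acid, would keep the low number of compound 2.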